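Three Measured Compounds and a Prediction on Lung Cancer Cells

A few compounds are considered here, and "the series" means these few. Any claim that something is new, unique, unknown or untested is made for them only; others in the source may bear on it.

In a functional assay on A549 cells (Homo sapiens) for cytotoxicity, read by sulforhodamine B assay, with a stated time of 48 h (a lower number here means a stronger inhibitor, a higher number a weaker inhibitor), compound 1 `CC(=O)OC[C@H]1O[C@@H](n2cc(Cn3cc([N+](=O)[O-])c4ccccc43)nn2)[C@H](OC(C)=O)[C@@H](OC(C)=O)[C@@H]1OC(C)=O` gives 93200 nM. In this assay compound 2 `CC(=O)OC[C@H]1O[C@@H](n2cc(CN3C(=O)/C(=C/c4ccc(C)cc4)c4ccccc43)nn2)[C@H](OC(C)=O)[C@@H](OC(C)=O)[C@@H]1OC(C)=O` gives 16000 nM. In this assay compound 3 `CC(=O)OC[C@H]1O[C@@H](n2cc(CN3C(=O)/C(=C\c4ccc(C)cc4)c4ccccc43)nn2)[C@H](OC(C)=O)[C@@H](OC(C)=O)[C@@H]1OC(C)=O` gives 16500 nM.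

Compound 3 stands second highest of these three numbers. Its nearest neighbour is compound 2, with a 1.0-fold higher number from compound 2 to compound 3 (0.01 log units; within the scatter), a step that lies within the scatter and rests on (the fact that compounds 2 and 3 differ only in the configuration as drawn). Compound 1 gives the highest number, beyond the scatter from compound 3.

Compound 4 `CC(=O)OC[C@H]1O[C@@H](n2cc(CN3C(=O)/C(=C\c4ccco4)c4ccccc43)nn2)[C@H](OC(C)=O)[C@@H](OC(C)=O)[C@@H]1OC(C)=O` differs from compound 3 by furan-2-yl in place of 4-methylphenyl on a double-bonded chain carbon bound to a double-bonded ring carbon. Within the data shown here, the one measured step, a 1.0-fold higher number from compound 2 to compound 3 (0.01 log units; within the scatter), leaves that group untouched, so no measured step bears on this exchange. The expectation is therefore no step beyond the scatter, a 1.0-fold lower number from compound 3 to compound 4 (0.01 log units; within the scatter). Compound 4 is estimated at 16000 nM in this assay, with a range from 6000 nM to 45000 nM.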

Compound 4, half-maximal inhibitory concentration: 41100 nM
Estimate against measurement, compound 4: 2.6-fold (0.41 log units) below; low and high end bracket the measured number.
By their numbers in this assay, from the lowest: compounds 2 and 3 (each within the scatter of the next); then compound 4; then compound 1.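

In this assay, furan-2-yl in place of 4-methylphenyl on a double-bonded chain carbon bound to a double-bonded ring carbon moves the number beyond the scatter (a 2.5-fold higher number from compound 3 to compound 4 (0.40 log units; beyond the scatter)). This shows that the group at this position can shift the read-out, which the change in drawn configuration (a 1.0-fold higher number from compound 2 to compound 3 (0.01 log units; within the scatter)) did not. Nothing given here accounts for this step. The compounds shown leave open how thiophen-2-yl or 4-aminophenyl would read at this position. They also leave open whether the drawn configuration of the double bond matters once furan-2-yl is present.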